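Hydroxymethyl to methoxy on a shared core

The source may report more compounds than this note shows. Statements on the series, on what has been measured and on what is new or still open speak of the compounds shown alone.

In a functional assay on BXPC-3 cells (Homo sapiens) for cytotoxicity, read by MTT assay, with a stated time of 72 h (on this read-out lower numbers stand for stronger inhibition and higher numbers for weaker inhibition), compound 1 (`Nc1ccc(-c2ccc(NC3=CC(=O)c4ncncc4C3=O)cc2)cc1`) gives 3500 nM and compound 2 (`O=C1C(Nc2ccc(CO)cc2)=CC(=O)c2ncncc21`) gives 5700 nM. Within the data shown here, these are the only two numbers available, and they lie within the scatter of each other, so compound 2 cannot be separated from compound 1.

Compound 3 (`COc1ccc(NC2=CC(=O)c3ncncc3C2=O)cc1`) keeps the shared core and differs from compound 2 in one place: methoxy in place of hydroxymethyl on an aromatic carbon. This puts methoxy in place of hydroxymethyl on an aromatic carbon, para to a large group. Among the measured compounds shown here, the two groups are thus isomeric replacements at the same site, but no measured pair makes this exchange, so the evidence is indirect.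

For the measured compounds named here, the single measured step bearing on it is a 1.6-fold higher number from compound 1 to compound 2 (0.21 log units; within the scatter). That step exchanged 4-aminophenyl for hydroxymethyl on an aromatic carbon, and it did not move the number beyond the scatter. With only this to go on, no step beyond the scatter is expected here, and the expected change is a 1.3-fold lower number from compound 2 to compound 3 (0.10 log units; within the scatter). For compound 3 the estimated value in this assay is 4500 nM, with an expected range of 1800 nM to 11000 nM.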

Compound 3, half-maximal inhibitory concentration: 1700 nM
Compound 3: middle estimate off by 2.6-fold (0.42 log units), on the high side, and the stated range ends above it.
By their numbers in this assay, from the lowest: compound 3; then compounds 1 and 2 (each within the scatter of the next).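

Among these compounds, at this site, on an aromatic carbon para to a large group, the exchange in this assay gives a 3.4-fold lower number from compound 2 to compound 3 (0.53 log units; beyond the scatter) and is the first step here to lie beyond the scatter, although both groups have the same heavy atoms, joined differently, and methoxy has 0 hydrogen-bond donors where hydroxymethyl has 1. Methoxy is also separated from 4-aminophenyl at the same site, with a 2.1-fold lower number from compound 1 to compound 3 (0.31 log units; beyond the scatter) as a second modest step, so compound 3 now stands as the most potent of the three, while compound 1 and compound 2 remain within the scatter of each other. No measurement offered here explains why the methoxy compound gives the lower number.

The compounds shown leave open whether the step follows the hydroxyl hydrogen of hydroxymethyl or the oxygen joined directly to the aromatic ring, a question that a plain hydroxyl, an ethoxy or a methoxymethyl group at this site would bear on. They also leave open how an amine or a carboxylic acid at the same site would compare with compound 3.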